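A few compounds are considered here, and "the series" means these few. Any claim that something is new, unique, unknown or untested is made for them only; others in the source may bear on it.

In a functional assay on MCF7 cells (Homo sapiens) for inhibition, read by MTT assay, with a stated time of 48 h (a lower number here means a stronger inhibitor, a higher number a weaker inhibitor), compound 1 `O=C(CC(c1cccs1)C(C(=O)Nc1ccccn1)C(=O)Nc1ccccn1)c1ccccc1` is reported as "not active" (no number reported), without a number. Compound 2 `O=C(CC(c1ccc(Cl)cc1Cl)C(C(=O)Nc1ccccn1)C(=O)Nc1ccccn1)c1ccccc1` gives 33400 nM, and compound 3 `O=C(CC(c1c(Cl)cccc1Cl)C(C(=O)Nc1ccccn1)C(=O)Nc1ccccn1)c1ccccc1` gives 16700 nM, so these two values stand within the scatter of each other. Compound 4 `Cc1cc(C)c(C(CC(=O)c2ccccc2)C(C(=O)Nc2ccccn2)C(=O)Nc2ccccn2)c(C)c1` has 2,4,6-trimethylphenyl in place of 2,6-dichlorophenyl on a saturated chain carbon bound to two saturated chain carbons, with 2,4,6-trimethylphenyl in place of 2,6-dichlorophenyl. Within the data shown here, the one measured step at that place, a 2.0-fold lower number from compound 2 to compound 3 (0.30 log units; within the scatter), exchanges one dichlorophenyl for another. Among the measured compounds shown here, no measured compound carries 2,4,6-trimethylphenyl, so this step is only a loose guide, and no step beyond the scatter is expected in this assay. The estimated step is a 1.2-fold higher number from compound 3 to compound 4 (0.08 log units; within the scatter). For compound 4 the expected value is 20000 nM, with an estimated range of 8000 nM to 50000 nM.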

Compound 4, half-maximal inhibitory concentration: 28800 nM
The estimate for compound 4 lay 1.4-fold (0.16 log units) below the measured number; the range from low to high includes it.
By their numbers in this assay, from the lowest: compounds 3, 4 and 2 (each within the scatter of the next).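

In this assay, putting 2,4,6-trimethylphenyl at this place gives a 1.7-fold higher number from compound 3 to compound 4 (0.24 log units; within the scatter) and a 1.2-fold lower number from compound 2 to compound 4 (0.06 log units; within the scatter). The earlier step only exchanged one dichlorophenyl for another, whereas compound 4 shows that a phenyl group without chlorine, carrying only carbon substituents, also stays within the scatter of both dichlorophenyl compounds. No measurement at hand explains this result.

On these data alone, it remains open whether an amine or a carboxylic acid on this phenyl group would move the number beyond the scatter, and how an unsubstituted phenyl would compare.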